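A few compounds are considered here, and "the series" means these few. Any claim that something is new, unique, unknown or untested is made for them only; others in the source may bear on it.

Of the compounds shown here, three built on one shared core have been measured in a functional assay on DU-145 cells (Homo sapiens) for inhibition, read by trypan blue exclusion, with a stated time of 72 h; a lower number here means a stronger inhibitor, a higher number a weaker inhibitor. Compound 1 `Cn1c(=O)c(S(=O)(=O)Nc2ccc(F)cc2F)cc2cnc(Nc3ccc4[nH]ccc4c3)nc21` gives 5000 nM. Compound 2 `Cn1c(=O)c(S(=O)(=O)c2ccccc2)cc2cnc(Nc3cnc4[nH]ccc4c3)nc21` gives 1000 nM, a lower number than compound 1 by a gap that lies beyond the usual scatter. Compound 3 `Cn1c(=O)c(S(=O)(=O)c2ccc(F)cc2)cc2cnc(Nc3ccc4cc[nH]c4c3)nc21` gives 10000 nM, and this sits within the scatter of the value of compound 1, so those two cannot be placed in order. Compound 1 therefore stands toward the weaker end of these three numbers, with only compound 2 clearly ahead of it.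

Compound 4 `Cn1c(=O)c(S(=O)(=O)c2ccc(N)cc2F)cc2cnc(Nc3ccc4[nH]ccc4c3)nc21` has not yet been measured. It differs from compound 1 in one place: 4-amino-2-fluorophenyl in place of (2,4-difluorophenyl)amino on a sulfonyl sulfur. Going by the values given here, compounds 2 and 3 each differ from compound 1 in more than one place, so no single step between measured compounds shows what this change alone does; their values fall on either side of compound 1, one lower and one within scatter. A modest gain is expected from compound 1 to compound 4 a 1.7-fold lower number from compound 1 to compound 4 (0.22 log units; within the scatter), but with little to anchor it. Compound 4 is estimated at 3000 nM in this assay, with a range from 600 nM to 15000 nM.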

Compound 4, half-maximal inhibitory concentration: 8000 nM
Beside the measured number, compound 4's estimate is 2.7-fold (0.43 log units) below it; the measured number falls inside the stated range.
By their numbers in this assay, from the lowest: compound 2; then compounds 1, 4 and 3 (each within the scatter of the next).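

In this assay, going by these compounds alone, the one step that changes a single place is a 1.6-fold higher number from compound 1 to compound 4 (0.20 log units; within the scatter), so putting 4-amino-2-fluorophenyl in place of (2,4-difluorophenyl)amino on a sulfonyl sulfur has no effect that can be told apart from repeat-to-repeat variation. This swap is not a small one on paper: the ring loses its amino link to the sulfur and sits on it directly, and a ring fluorine gives way to an amino group, yet the two numbers cannot be placed in order. Nothing on hand gives a reason for this outcome.

The step also bundles those two differences together, so it cannot say whether each one alone is silent or whether they offset each other. A carboxylic acid or a morpholine in place of the amino group on that ring, or a longer carbon chain linking the ring to the sulfur, would test whether changes at this position can ever move the number beyond the scatter.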